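Chloro to hydroxy swap on the anilide ring

The source may report more compounds than this note shows. Statements on the series, on what has been measured and on what is new or still open speak of the compounds shown alone.

Compound 1 `Cc1ccc2occ(C(=O)Nc3ccc(Cl)cc3)c(=O)c2c1` gives 45.4 nM in an assay on cells for inhibition of Amine oxidase [flavin-containing] B (Homo sapiens), read by fluorescence and Amplex Red, using microsomes, with a stated time of 15 min; a higher number here means a weaker inhibitor, a lower number a stronger inhibitor. Compound 2 `Cc1ccc2occ(C(=O)Nc3ccc(O)cc3)c(=O)c2c1` gives 513 nM in this assay. The step between them, an 11-fold higher number from compound 1 to compound 2 (1.05 log units; beyond the scatter), arises from the change (hydroxy in place of chloro on an aromatic carbon). Compound 3 `COc1ccc2occ(C(=O)Nc3cccc(Cl)c3)c(=O)c2c1` gives 3.94 nM in this assay, the lowest number among the three measured compounds; the difference between the cores of compound 1 and compound 3 is not broken down here. Compound 4 `COc1ccc2occ(C(=O)Nc3cccc(O)c3)c(=O)c2c1` has not yet been measured. It differs from compound 3 by hydroxy in place of chloro on an aromatic carbon. In the measured pair the hydroxy enters para to a large group, whereas here it enters meta to a large group, so this is the same kind of change, not the same change. Within the data shown here, compound 4 is expected to show a step of a 10-fold higher number from compound 3 to compound 4 (1.01 log units; beyond the scatter), an expectation resting on the size of an 11-fold higher number from compound 1 to compound 2 (1.05 log units; beyond the scatter) as the only measured instance of this swap. Compound 4 is therefore estimated at 40 nM in this assay, with a range of 12 nM to 130 nM to allow for the different surroundings of the change.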

Compound 4, half-maximal inhibitory concentration: 114 nM
The estimate for compound 4 lay 2.9-fold (0.45 log units) below the measured number; measured number inside the range.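

In this assay hydroxy in place of chloro gives a 29-fold higher number from compound 3 to compound 4 (1.46 log units; beyond the scatter), so the swap weakens inhibition on both cores shown, and the two steps cannot be told apart in size: the same change on two cores in this assay, an 11-fold higher number (1.05 log units; beyond the scatter) from compound 1 to compound 2 and a 29-fold higher number (1.46 log units; beyond the scatter) from compound 3 to compound 4, 2.6-fold (0.41 log units) apart, within the scatter of two such steps

This agreement supports carrying the size of the step from one of these cores to the other, at least as a rough guide for this swap. Among these compounds, it rests on only two pairs, however, and those pairs differ both in the core and in where the swap sits on the anilide ring, so neither influence can be separated from the other, and nothing follows for cores outside this set.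

Among the compounds shown, no pair keeps the core fixed while moving the chloro or the hydroxy, so the separate contribution of position remains open. On these data alone, whether an amine, a nitrile or a carboxylic acid in place of chloro would give a step of similar size also remains open, as does whether the rise in the number is particular to hydroxy.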